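Substituent changes on the amine aryl group of the shared core

The compounds below may be only part of what the source reports. "The series", "measured", "known", "first", "only" and "open" are said of these compounds alone.

Measured compounds in a functional assay on ECa-109 cells for inhibition, with ECa-109 cell line (Homo sapiens) as the target, read by sulforhodamine B assay; a higher number here means a weaker inhibitor, a lower number a stronger inhibitor:
Compound 1 `Cc1ccc(NC2=CC(=O)c3nc4n(c3C2=O)[C@H]2OC[C@@H](O)[C@H]2OC4)cc1C`: 2820 nM
Compound 2 `O=C1C=C(NCc2ccccc2)C(=O)c2c1nc1n2[C@H]2OC[C@@H](O)[C@H]2OC1`: > 8000 nM, which is a limit of the assay and not a number.
Compound 3 `O=C1C=C(Nc2ccccc2)C(=O)c2c1nc1n2[C@H]2OC[C@@H](O)[C@H]2OC1`: 4970 nM

Compound 3 stands with compound 1 inside the usual scatter: a 1.8-fold higher number from compound 1 to compound 3 (0.25 log units; within the scatter). Compound 2 contributes only a limit; of its pair with compound 3 the data say an at least 1.6-fold lower number from compound 2 to compound 3 (0.20 log units; that floor lies within the scatter).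

The next compound, compound 4 `O=C1C=C(Nc2ccc(C(F)(F)F)cc2)C(=O)c2c1nc1n2[C@H]2OC[C@@H](O)[C@H]2OC1`, has not been measured. It differs from compound 3 by trifluoromethyl in place of hydrogen on an aromatic carbon. Within the data shown here, the only measured step on the same ring, a 1.8-fold higher number from compound 1 to compound 3 (0.25 log units; within the scatter), shows that adding or removing substituents on the aryl ring of this series moved this assay less than the scatter. The step from compound 2 to compound 3 changes the link to the ring, not its substitution, and does not bear directly on compound 4.

No step beyond the scatter is therefore expected for compound 4: a 1.1-fold lower number from compound 3 to compound 4 (0.04 log units; within the scatter). Compound 4 is estimated at 4500 nM in this assay, with a range from 1800 nM to 11000 nM.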

Compound 4, half-maximal inhibitory concentration: 5500 nM
Compound 4: the middle estimate sits 1.2-fold (0.09 log units) below what was measured; the range from low to high includes it.
By their numbers in this assay, from the lowest: compounds 1, 3 and 4 (each within the scatter of the next). At a limit, above all of these: compound 2.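

In this assay, trifluoromethyl on an aromatic carbon, para to a large group, is the first substituent shown on the plain phenyl of compound 3, and it brings no step beyond the scatter: a 1.1-fold higher number from compound 3 to compound 4 (0.04 log units; within the scatter). The comparison with the two methyl groups of the 3,4-dimethylphenyl also stays inside the scatter, a 2.0-fold higher number from compound 1 to compound 4 (0.29 log units; within the scatter), so the aryl amines compound 1, compound 3 and compound 4 cannot be told apart here, even with a group of four heavy atoms entering. Against the benzyl amine only a floor can be given: an at least 1.4-fold lower number from compound 2 to compound 4 (0.16 log units; that floor lies within the scatter). Compound 2 gives only a limit of the assay, so this step cannot be read as a size: the limit of > 8000 nM in this assay, at which 1 of the 4 values shown sits.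

As far as these compounds go, whether a hydroxyl, an amine or a carboxylic acid on this ring would move the number beyond the scatter remains open. Also open, from the compounds shown here alone, is whether any aryl amine at this nitrogen separates from the others in this assay.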